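The source may report more compounds than this note shows. Statements on the series, on what has been measured and on what is new or still open speak of the compounds shown alone.

Compound 1 `O=C(O)c1ccccc1-c1ccc(CCc2ncc(C3CCCCC3)[nH]2)cc1` gives 375 nM in an in vitro functional assay on cells for agonist activity at Bombesin receptor subtype-3 (Homo sapiens), read by luminescence and calcium flux; on this read-out higher numbers stand for an effect only at larger amounts of compound and lower numbers for an effect already at smaller amounts. Among the three measured numbers it stands second highest. Compound 2 `O=C(O)c1ccccc1-c1ccc(CCc2ncc(CC3CCOCC3)[nH]2)cc1` gives 338 nM in this assay, and a 1.1-fold lower number from compound 1 to compound 2 (0.05 log units; within the scatter). Compound 3 `O=C(O)c1ccccc1-c1ccc(CCc2ncc(Cc3ccc(Cl)cc3)[nH]2)cc1` gives 2290 nM in this assay, and a 6.1-fold higher number from compound 1 to compound 3 (0.79 log units; beyond the scatter); likewise a 6.8-fold higher number from compound 2 to compound 3 (0.83 log units; beyond the scatter). Compound 4 `CC(C)(C)Cc1cnc(CCc2ccc(-c3ccccc3C(=O)O)cc2)[nH]1` differs from compound 1 in one place: neopentyl in place of cyclohexyl on an aromatic carbon. The step to compound 2 shows that exchanging cyclohexyl for another non-aromatic group leaves the number within the scatter, whereas the steps to compound 3 show a modest rise only where the 4-chlorophenyl enters. Neopentyl carries no ring and is not aromatic, so no step beyond the scatter is expected for compound 4 in this assay, namely a 1.1-fold higher number from compound 1 to compound 4 (0.03 log units; within the scatter). Compound 4 is estimated at 400 nM, between 180 nM and 900 nM.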

Compound 4, half-maximal effective concentration: 106 nM
Compound 4: the middle estimate sits 3.8-fold (0.58 log units) above what was measured, and the stated range ends above it.
By their numbers in this assay, from the lowest: compound 4; then compounds 2 and 1 (each within the scatter of the next); then compound 3.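

In this assay, this aromatic carbon of the five-membered ring proves sensitive to exchanges among non-aromatic groups, which the earlier cyclohexyl to (oxan-4-yl)methyl exchange did not reveal: neopentyl gives a 3.5-fold lower number from compound 1 to compound 4 (0.55 log units; beyond the scatter) and a 3.2-fold lower number from compound 2 to compound 4 (0.50 log units; beyond the scatter). Set against the 4-chlorobenzyl group, the same neopentyl gives a 22-fold lower number from compound 3 to compound 4 (1.33 log units; beyond the scatter), the largest step in the series so far. No data shown here account for these steps. Still open, on these data alone, is how a shorter isobutyl or a longer 3,3-dimethylbutyl chain would read at this carbon, and whether an amine on the chain would be tolerated.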